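Three triazolothiadiazoles and an untested fourth in rat paw edema

The source may hold more compounds than are shown below. What is called first, only, known or untested is meant among the compounds shown, and "the series" means these compounds.

Compound 1 `COc1ccc(Cl)c(-c2nnc3sc(Cc4c[nH]c5ccc(OC)cc45)nn23)c1`: 33.9%
Compound 2 `COc1ccc2[nH]cc(Cc3nn4c(Cc5ccc(OC)c(OC)c5)nnc4s3)c2c1`: 29.6%
Compound 3 `COc1ccc(Cl)c(-c2nnc3sc(Cc4c[nH]c5ccccc45)nn23)c1`: 34.7%

All three measured compounds were tested in a functional assay on the whole organism (strain Wistar Albino) for inhibition, with Rattus norvegicus as the target, read by paw edema, with a stated time of 4 h, at a dose of 20 mg/kg; a higher number here means more inhibition at the dose given (going by the name of the read-out), a lower number less inhibition. In this assay compound 1 gives 33.9%, compound 2 gives 29.6% and compound 3 gives 34.7%; the gaps between any two of these numbers fall within the usual scatter of repeated measurements, so none of the three can be set apart from the others.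

Compound 3 is derived from compound 1 by one change, (hydrogen in place of methoxy on an aromatic carbon), and this change made a step of a number 0.8 percentage points higher from compound 1 to compound 3 (within the scatter), which is within the scatter.

Compound 4 `COc1ccc(Cc2nnc3sc(Cc4c[nH]c5ccccc45)nn23)cc1OC` has not yet been measured. It stands to compound 2 as compound 3 stands to compound 1: the change is hydrogen in place of methoxy on an aromatic carbon, and the place where it happens is described in the same words in both cases, so it is the same change made on a different core. How the core of compound 2 differs from the core of compound 1 is not broken down here.

Because the same change gave a number 0.8 percentage points higher from compound 1 to compound 3 (within the scatter), a step of similar size is expected from compound 2 to compound 4, namely a number 0.8 percentage points higher from compound 2 to compound 4 (within the scatter). Compound 4 is therefore estimated to give 30.4% in this assay, with a likely range from 22% to 39%.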

Compound 4, a percentage reported as inhibition, in the whole organism at one dose (the size of the read-out at that dose, not a potency): 28.5%
Beside the measured number, compound 4's estimate is 1.9 percentage points above it; measured number inside the range.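

In this assay, putting hydrogen in place of methoxy on the core of compound 2 gives a number 1.1 percentage points lower from compound 2 to compound 4 (within the scatter). Set beside the earlier case, the two steps do not differ: the same change on two cores in this assay, a number 0.8 percentage points higher (within the scatter) from compound 1 to compound 3 and a number 1.1 percentage points lower (within the scatter) from compound 2 to compound 4, 1.9 percentage points apart, within the scatter of two such steps

This shows that, on these two cores, the change leaves the read-out unmoved within the usual scatter, so the small step seen on the first core was a fair guide to the second, but it does not show that the methoxy group is without any effect, since a small real effect could be hidden in the scatter, and two pairs cannot establish a rule for the whole series.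

Among the compounds shown, this place on the aromatic ring carries only methoxy or hydrogen, so what an amine, a carboxylic acid or a longer chain would do there remains open, as does whether any such group would produce a step large enough to stand clear of the scatter and to be tested on both cores. As far as these compounds go, with every number taken at a single dose and a single time, it also remains open how these compounds would compare at other doses or at other times.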